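Compound 3 to compound 4: fluoro in place of methyl

The source may hold more compounds than are shown below. What is called first, only, known or untested is meant among the compounds shown, and "the series" means these compounds.

Measured in a functional assay on A549 cells (Homo sapiens) for inhibition, read by CCK-8 assay, with a stated time of 72 h, tested at 8 uM; on this read-out lower numbers stand for less inhibition of growth and higher numbers for more inhibition of growth at the one concentration tested:
- compound 1 `Cc1cc(C)cc(SCc2ccc(/C=C/C(=O)Nc3ccccc3N)cc2)c1`: 47.3%
- compound 2 `Nc1ccccc1NC(=O)/C=C/c1ccc(CSc2cccc(F)c2)cc1`: 56.6%
- compound 3 `Cc1ccc(SCc2ccc(/C=C/C(=O)Nc3ccccc3N)cc2)cc1`: 48.3%

Compound 3, at 48.3%, lies within the scatter of both other compounds. The change to compound 4 `Nc1ccccc1NC(=O)/C=C/c1ccc(CSc2ccc(F)cc2)cc1` is fluoro in place of methyl on an aromatic carbon, para to a large group: fluoro in place of methyl on an aromatic carbon. Going by the values given here, no measured step matches it exactly. The nearest is 4-methylphenyl in place of 3-fluorophenyl on a sulfur, a number 8.3 percentage points lower from compound 2 to compound 3 (within the scatter). The other two steps on that sulfur are a number 9.3 percentage points higher from compound 1 to compound 2 (within the scatter) and a number 1 percentage points higher from compound 1 to compound 3 (within the scatter). No step beyond the scatter is therefore expected in this assay. The estimated step is a number 3.7 percentage points higher from compound 3 to compound 4 (within the scatter). For compound 4 the expected value is 52%, with an estimated range of 42% to 62%.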

Compound 4, percent growth inhibition at one concentration: 59.1%
The estimate for compound 4 lay 7.1 percentage points below the measured number, and the stated range covers the measured number.
By their numbers in this assay, from the lowest: compounds 1, 3, 2 and 4 (each within the scatter of the next, the first and the last beyond it).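

In this assay, going by these compounds alone, fluoro in place of methyl at this position gives a number 10.8 percentage points higher from compound 3 to compound 4 (beyond the scatter), the first step beyond the scatter, and 4-fluorophenyl in place of 3,5-dimethylphenyl on the sulfur gives a number 11.8 percentage points higher from compound 1 to compound 4 (beyond the scatter) as well. Moving the fluoro, 4-fluorophenyl in place of 3-fluorophenyl, gives only a number 2.5 percentage points higher from compound 2 to compound 4 (within the scatter), and compound 2 goes against a general fluoro-over-methyl reading, since its steps to compound 1 and compound 3 stay within the scatter. No measurement here bears on the reason for these steps.

Open, on these data alone, is whether a chloro, a methoxy or an amine at the same position would read like fluoro or like methyl.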